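A few compounds are considered here, and "the series" means these few. Any claim that something is new, unique, unknown or untested is made for them only; others in the source may bear on it.

Three analogues of one shared core have been read in an assay for inhibition of acid-sensing ion channel 3 (Homo sapiens), read by patch clamp, tested at 1 uM; on this read-out higher numbers stand for more inhibition at the one concentration tested (going by the name of the read-out) and lower numbers for less inhibition. Compound 1 `C=CCNc1nc(N)c(C(=O)N=C(N)N)nc1Cl` carries an allylamino group on the ring carbon that in the other two compounds bears a larger substituent; in this assay compound 1 gives 16%. This is the lowest of the three numbers. Compound 2 `NC(N)=NC(=O)c1nc(Cl)c(NCc2ccc3ccccc3c2)nc1N` gives 27% in this assay, a step up from compound 1 that lies beyond the scatter. Compound 3 `NC(N)=NC(=O)c1nc(Cl)c(Nc2ccc3ncccc3c2)nc1N` gives 41% in this assay, the furthest from compound 1, also beyond the scatter.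

Compound 4 `COc1nc(N)c(C(=O)N=C(N)N)nc1Cl` has not been measured in this assay. It differs from compound 1 in one place: methoxy in place of allylamino on an aromatic carbon. Two heavy atoms thus replace four, and the hydrogen-bond donor of the allylamino group is gone, while one acceptor remains.

For the measured compounds named here, no pair that differs in one place has been measured, so there is no step to lean on. Within the three measured compounds, the two larger substituents at this position, in compound 2 and compound 3, sit higher than the allylamino group of compound 1. A smaller group is not expected to recover that; compound 4 is estimated at 10% in this assay, within 0% to 25%. The expected step from compound 1 to compound 4 in this assay is a number 6 percentage points lower from compound 1 to compound 4 (within the scatter), that is, no change beyond the scatter, leaning downward.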

Compound 4, a percentage reported as inhibition, at one concentration (the size of the read-out at that concentration, not a potency): 21%
Compound 4: the middle estimate sits 11 percentage points below what was measured; low and high end bracket the measured number.
By their numbers in this assay, from the lowest: compounds 1, 4 and 2 (each within the scatter of the next, the first and the last beyond it); then compound 3.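

For the compounds shown here, the step in this assay is a number 5 percentage points higher from compound 1 to compound 4 (within the scatter), and this is the first pair that differs in one place. At this aromatic carbon, next to the ring nitrogen, the read-out does not separate methoxy from allylamino, even though the exchange removes the hydrogen-bond donor and the double bond and leaves fewer heavy atoms. This single pair therefore gives no sign that the hydrogen-bond donor or the double bond of allylamino matters for inhibition at the one concentration tested, and no measured evidence bearing on the result is available.

Open, from the compounds shown here alone, is how a plain amino group, a hydroxyl or a longer chain such as butoxy would read at this carbon, each set against compound 1 or compound 4 as a change in one place. A benzyloxy group there would show whether a substituent without the hydrogen-bond donor also stays within the scatter of compound 4 when it carries a ring.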